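Carbinol side-chain variation on the shared core

This account rests on a few compounds, and the source may have more. Where it says the series, first, only, none or still open, it means among the compounds named here.

compound 1 `OC(CCn1nc2c(Br)c(Br)c(Br)c(Br)c2n1)c1cccc(Cl)c1`: 0%
compound 2 `C[C@@H](O)CCn1nc2c(Br)c(Br)c(Br)c(Br)c2n1`: 23%
compound 3 `OC(CCn1nc2c(Br)c(Br)c(Br)c(Br)c2n1)c1ccccc1`: 0%

In a functional assay on CCRF-CEM cells (Homo sapiens) for antiproliferative activity, read by MTT assay, with a stated time of 48 h, tested at 50 uM (on this read-out higher numbers stand for a weaker effect at the one concentration tested and lower numbers for a stronger effect), compound 3 gives 0% and compound 1 gives 0%, level at the digits shown and together the lowest of the three numbers. Compound 2 gives 23%, a number higher than compound 3 beyond the scatter. Among the measured compounds shown here, the only measured step, no change at the digits printed from compound 1 to compound 3 (within the scatter), alters the aromatic substituent and leaves the carbinol carbon untouched, so it says little about the next change. Compound 4 `CC(O)CCn1nc2c(Br)c(Br)c(Br)c(Br)c2n1` differs from compound 3 by methyl in place of phenyl on a saturated chain carbon bound to an oxygen on a saturated carbon and a saturated chain carbon. For the measured compounds named here, no measured step bears on this exchange directly; the nearest guide is compound 2, which carries methyl at that carbon as a single stereoisomer. On that basis compound 4 is expected to move by a number 20 percentage points higher from compound 3 to compound 4 (beyond the scatter), to an estimated 20% with a range of 0% to 40%.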

Compound 4, a percentage reported as activity, at one concentration (the size of the read-out at that concentration, not a potency): 45%
Estimate against measurement, compound 4: 25 percentage points below; the measured number lies above the stated range.
By their numbers in this assay, from the lowest: compounds 1 and 3 (each within the scatter of the next); then compound 2; then compound 4.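

In this assay, the position proves sensitive to the size of the group only when the ring is lost: a number 45 percentage points higher from compound 3 to compound 4 (beyond the scatter), and with methyl in place of 3-chlorophenyl, a number 45 percentage points higher from compound 1 to compound 4 (beyond the scatter). Identical atoms and bonds also do not ensure one number at this position: a number 22 percentage points higher from compound 2 to compound 4 (beyond the scatter). The only difference on record for that step is this: the fact that one of compounds 2 and 4 is drawn with a defined configuration and the other without, at the place where they differ

As far as these compounds go, how compound 4 divides between its stereoisomers, and what the S form alone gives, remains open. So does the reading of a longer chain, an amine or a carboxylic acid at this position.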